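Swapping an Aldehyde-Bearing Phenyl for a Thiophene

This account rests on a few compounds, and the source may have more. Where it says the series, first, only, none or still open, it means among the compounds named here.

Compound 1 `c1ccc(-c2cn3ccnc3c(-c3ccc4ncn(C5CCCCC5)c4c3)n2)cc1`: 67.1%
Compound 2 `O=Cc1ccc(-c2cn3ccnc3c(-c3ccc4ncn(C5CCCCC5)c4c3)n2)cc1`: 16.5%

For the measured compounds named here, in a functional assay on HL-60 cells (Homo sapiens) for inhibition, read by sulforhodamine B assay, with a stated time of 48 h, tested at 10 uM (a lower number here means less inhibition, a higher number more inhibition at the concentration tested (going by the name of the read-out)), compound 2 gives 16.5%, the lower of the two numbers measured so far; compound 1 gives 67.1%. Compound 3 `c1cn2cc(-c3ccsc3)nc(-c3ccc4ncn(C5CCCCC5)c4c3)c2n1` differs from compound 2 in one place: thiophen-3-yl in place of 4-formylphenyl on an aromatic carbon. Going by the values given here, only one measured step bears on this change. Because a number 50.6 percentage points lower from compound 1 to compound 2 (beyond the scatter) shows that the formyl group costs a large part of the inhibition, and compound 3 loses the 4-formylphenyl altogether, a rise back toward compound 1 is expected, a number 38.5 percentage points higher from compound 2 to compound 3 (beyond the scatter). Compound 3 is therefore estimated at 55%, between 30% and 75%.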

Compound 3, a percentage reported as inhibition, at one concentration (the size of the read-out at that concentration, not a potency): 18.5%
For compound 3 the middle estimate is 36.5 percentage points above the measured one; the measured number lies below the stated range.
By their numbers in this assay, from the lowest: compounds 2 and 3 (each within the scatter of the next); then compound 1.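

In this assay, thiophen-3-yl in place of 4-formylphenyl gives a number 2 percentage points higher from compound 2 to compound 3 (within the scatter), so these two groups cannot be told apart here. Thiophen-3-yl in place of phenyl gives a number 48.6 percentage points lower from compound 1 to compound 3 (beyond the scatter), so removing the formyl does not by itself restore inhibition, and of these three groups only the plain phenyl of compound 1 keeps it high. No measurement at hand explains why two such different groups give matching numbers.

Still open, going by these compounds, is whether a phenyl bearing an amine or a carboxylic acid in place of the formyl would stay with compound 1 or fall with compound 2.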